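A few compounds are considered here, and "the series" means these few. Any claim that something is new, unique, unknown or untested is made for them only; others in the source may bear on it.

Measured so far:
Compound 1 `c1ccc(Cn2c(Nc3ccccc3)nc3ncccc32)cc1`: in a functional assay on HCT-116 cells (Homo sapiens) for antiproliferative activity, read by MTT assay, with a stated time of 72 h (on this read-out higher numbers stand for weaker inhibition of growth and lower numbers for stronger inhibition of growth), compound 1 gives 64700 nM.
Compound 2 `O=[N+]([O-])c1cccc(Nc2nc3ncccc3n2Cc2ccccc2)c1`: compound 2 gives 41700 nM.
Compound 3 `Cn1nc(-c2ccnc(Nc3cccc(O)c3)n2)c2ccccc21`: compound 3 gives 17200 nM.

Compound 3 has the lowest of the three numbers in this assay, and its gap to compound 2 as well as to compound 1 lies beyond the scatter. Compound 4 `Cn1nc(-c2ccnc(Nc3cccc(Cl)c3)n2)c2ccccc21` differs from compound 3 by chloro in place of hydroxy on an aromatic carbon. Within the data shown here, the only measured step, a 1.6-fold lower number from compound 1 to compound 2 (0.19 log units; within the scatter), concerns another substituent on another core and offers no direct guide to exchanging hydroxy for chloro. With nothing closer to rest on, compound 4 is expected to show a step of a 1.1-fold lower number from compound 3 to compound 4 (0.06 log units; within the scatter), staying near compound 3. Compound 4 is estimated at 15000 nM, with a range from 5000 nM to 45000 nM.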

Compound 4, concentration for 50% growth inhibition: 6400 nM
Estimate against measurement, compound 4: 2.3-fold (0.37 log units) above, within the range that was stated.
By their numbers in this assay, from the lowest: compound 4; then compound 3; then compounds 2 and 1 (each within the scatter of the next).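

In this assay, chloro in place of hydroxy on the aromatic carbon meta to a large group gives a 2.7-fold lower number from compound 3 to compound 4 (0.43 log units; beyond the scatter), a modest change but one beyond the scatter. The earlier step, a 1.6-fold lower number from compound 1 to compound 2 (0.19 log units; within the scatter), lay within the scatter and on another core, so this is the only single-place change shown to shift the number. Nothing measured here accounts for the step. As far as these compounds go, whether an amine or a methoxy group at this place would give a lower or higher number stays open, as does whether chloro would shift the number on the core of compound 1.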